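Ethylamino to dimethylamino on two cores: compounds 1 to 4

The source may report more compounds than this note shows. Statements on the series, on what has been measured and on what is new or still open speak of the compounds shown alone.

Measured in a functional assay on HCT-8 cells (Homo sapiens) for antiproliferative activity, read by MTT assay, with a stated time of 48 h; a lower number here means a stronger inhibitor, a higher number a weaker inhibitor:
compound 1, `CCNCC(=O)Nc1cc(OC)ccc1C(=O)c1ccc(OC)c2c1C=CC(C)(C)O2`, compound 1 gives 7890 nM
compound 2, `COc1ccc(C(=O)c2ccc(OC)c3c2C=CC(C)(C)O3)c(NC(=O)CN(C)C)c1`, compound 2 gives 5660 nM
compound 3, `C=C(c1ccc(OC)cc1NC(=O)CNCC)c1ccc(OC)c2c1OC(C)(C)C=C2`, compound 3 gives 1380 nM

Compound 1 and compound 2 share one core and differ only in the amine: dimethylamino in place of ethylamino on a saturated chain carbon bound to a carbonyl carbon. The step is a 1.4-fold lower number from compound 1 to compound 2 (0.14 log units; within the scatter), so on this core the two amines are not separated by the measurement.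

Compound 3 carries a different core; the difference between the core of compound 1 and the core of compound 3 is not broken down here. Compound 3 has the lowest number of the three, and its gaps to compound 2 and to compound 1 both lie beyond the scatter, so among the measured compounds it is the strongest inhibitor.

Compound 4, `C=C(c1ccc(OC)cc1NC(=O)CN(C)C)c1ccc(OC)c2c1OC(C)(C)C=C2`, is the counterpart of compound 3 with the same change already seen on the first core: dimethylamino in place of ethylamino on a saturated chain carbon bound to a carbonyl carbon, at the same place.

The step from compound 3 to compound 4 is expected to be small, a 1.4-fold lower number from compound 3 to compound 4 (0.14 log units; within the scatter), because the same change gave a 1.4-fold lower number from compound 1 to compound 2 (0.14 log units; within the scatter) on the core of compound 1. Compound 4 is thus estimated at 1000 nM, with a likely range from 400 nM to 2500 nM.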

Compound 4, half-maximal inhibitory concentration: 690 nM
The estimate for compound 4 lay 1.4-fold (0.16 log units) above the measured number; low and high end bracket the measured number.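

In this assay, replacing ethylamino with dimethylamino gives a 2.0-fold lower number from compound 3 to compound 4 (0.30 log units; within the scatter), so the two amines are not separated by the measurement on the core of compound 3 either. Set beside the earlier step, the change carries across both cores without a detectable difference in its size: the same change on two cores in this assay, a 1.4-fold lower number (0.14 log units; within the scatter) from compound 1 to compound 2 and a 2.0-fold lower number (0.30 log units; within the scatter) from compound 3 to compound 4, 1.4-fold (0.16 log units) apart, within the scatter of two such steps

This supports treating the two amines as interchangeable within the scatter on these two cores, but it does not establish a real gain from dimethylamino on either core, and two pairs cannot show that the result extends to a further core.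

Still open, on these data alone, is how a cyclic amine such as pyrrolidine or morpholine, or an unsubstituted amino group, would read on a saturated chain carbon bound to a carbonyl carbon, and whether a longer chain would keep the two cores in step. Also open is which part of the difference between the core of compound 1 and the core of compound 3 accounts for the gap between their values.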